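Replacing a Chlorophenyl with a Fluoropyridinyl: Tolerability Outlook

The source may hold more compounds than are shown below. What is called first, only, known or untested is meant among the compounds shown, and "the series" means these compounds.

Compound 1 `O=C(O)c1cccc(-c2ccc(/C=C3\S/C(=N\c4ccc(Cl)cc4)N(c4ccc(Cl)cc4)C3=O)o2)c1` gives > 200000 nM in an ADME assay on Vero cells (Chlorocebus sabaeus) for cytotoxicity (a higher number here means that more compound is tolerated, a lower number that less compound is tolerated), which is a limit of the assay rather than a number.
Compound 2 `O=C(O)c1cccc(-c2ccc(/C=C3\S/C(=N\c4ccccc4)N(c4ccc(Cl)cc4)C3=O)o2)c1` gives > 200000 nM in this assay, again only a limit.
Compound 3 `O=C(O)c1cccc(-c2ccc(/C=C3\S/C(=N\c4ccc(Cl)cc4)N(c4ccccn4)C3=O)o2)c1` gives > 200000 nM in this assay, also a limit.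

Compound 2 thus stands at the limit of > 200000 nM in this assay, at which 3 of the 3 values shown sit, and with every value shown being a limit, no order among the three compounds can be read. The unmeasured compound 4 `O=C(O)c1cccc(-c2ccc(/C=C3\S/C(=N\c4ccccc4)N(c4ccc(F)cn4)C3=O)o2)c1` differs from compound 2 in one place: 5-fluoropyridin-2-yl in place of 4-chlorophenyl on an amide-type nitrogen in a ring. Among the compounds with values here, two measured steps touch this kind of change. The first, a step that the two limits leave unreadable from compound 1 to compound 2, alters a chloro on the other aromatic ring. The second, a step that the two limits leave unreadable from compound 1 to compound 3, swaps the group on the same ring nitrogen that changes here. Neither step can be sized, so no shift beyond the scatter is expected in this assay. Compound 4 is expected to give 250000 nM, most likely again as a limit, within 100000 nM to 600000 nM. The step implied, a step that the limit leaves unreadable from compound 2 to compound 4, is an estimate of no change.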

Compound 4, half-maximal cytotoxic concentration: > 200000 nM
Compound 4: no number, only a limit; the forecaster's own chance of this, stated with the estimate: 85%; the middle value is on the limit's open side.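

Within the data shown here, compound 4 gives > 200000 nM in this assay, which is only a limit, so no step from compound 2 to compound 4 can be read. The compounds shown leave open at what concentration any of them becomes toxic to the cells, since all sit at one value: the limit of > 200000 nM in this assay, at which 4 of the 4 values shown sit.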